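Swapping tert-butoxy for pyridin-2-yl: a solubility outlook

The source may report more compounds than this note shows. Statements on the series, on what has been measured and on what is new or still open speak of the compounds shown alone.

Compound 1 `COc1ccc2[nH]c(C(=O)N3CC(=O)N(Cc4ccccc4)[C@@H](CN4CCCC4)C3)cc2c1` in a physicochemical assay for solubility, read by spectrophotometry, in phosphate buffer, with a stated time of 2 h, at pH 7.4 (on this read-out lower numbers stand for lower solubility and higher numbers for higher solubility), gives > 25000 nM, which is a limit of the assay and not a number. Compound 2 `COc1ccc2[nH]c(C(=O)N3CC(=O)N(Cc4ccccc4)[C@@H](COC(C)(C)C)C3)cc2c1` in this assay gives 65500 nM.

Compound 2 holds the only real number shown; the other result, for compound 1, is a limit (the limit of > 25000 nM in this assay, at which 1 of the 2 values shown sits). Within the data shown here, the one measured step, a step that the limit leaves unreadable from compound 1 to compound 2, cannot be read for size for that reason.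

Compound 3 `COc1ccc2[nH]c(C(=O)N3CC(=O)N(Cc4ccccc4)[C@@H](Cc4ccccn4)C3)cc2c1` differs from compound 2 by pyridin-2-yl in place of tert-butoxy on a saturated chain carbon bound to a saturated ring carbon. Among the measured compounds shown here, no measured step with a readable size bears on this change, so nothing here points to a direction beyond the scatter, and the expectation leans on compound 2 alone, with a wide range. Compound 3 is therefore expected to give about 45000 nM, with a range from 12000 nM to 150000 nM, an expected step of a 1.5-fold lower number from compound 2 to compound 3 (0.16 log units; within the scatter).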

Compound 3, solubility: > 100000 nM
Compound 3: a limit, no number; the forecaster's own chance of this, stated with the estimate: 30%; middle value at least 2.2-fold (0.34 log units) away from the limit.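

Compound 3 reads > 100000 nM in this assay, which is a limit and not a number. Pyridin-2-yl in place of tert-butoxy on a saturated chain carbon bound to a saturated ring carbon gives an at least 1.5-fold higher number from compound 2 to compound 3 (0.18 log units; that floor lies within the scatter), so a six-membered aromatic ring can sit here without the number falling, though the floor of this step alone shows no rise beyond the scatter. Among these compounds, all steps that involve compound 1 cannot be read, so this is the only step at this position with a readable size.

From the compounds shown here alone, how far compound 3 truly lies from compound 2 stays open, since only a floor is known. Also open, going by these compounds, is how a phenyl group or a carboxylic acid on this same chain carbon would read in this assay.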